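Swapping a halogen on a weakly active triazole pair

The source may report more compounds than this note shows. Statements on the series, on what has been measured and on what is new or still open speak of the compounds shown alone.

The measured compounds, all three tested in a functional assay on HT-29 cells (Homo sapiens) for inhibition, read by MTT assay, with a stated time of 48 h; a lower number here means a stronger inhibitor, a higher number a weaker inhibitor:
- compound 1 `Sc1nnc(Sc2nnc(-c3ccccc3)n2-c2ccccc2)n1-c1ccccc1`: 28300 nM
- compound 2 `Sc1nnc(CSc2nnc(-c3ccccc3)n2-c2ccccc2)n1-c1ccc(Cl)cc1`: 36600 nM
- compound 3 `CCOc1ccc(-n2c(S)nnc2Sc2nnc(-c3ccccc3)n2-c2ccccc2)cc1`: 46800 nM

All three numbers are high, so none of these compounds is a strong inhibitor in this assay. Compound 2 sits among them with its value; its gaps to compound 1 and to compound 3 are both within the scatter, so no order can be read between the three. Within the data shown here, the one change that can be followed, from compound 1 to compound 3, brings ethoxy in place of hydrogen on an aromatic carbon and gives a 1.7-fold higher number from compound 1 to compound 3 (0.22 log units; within the scatter), again within the scatter.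

Compound 4 `Fc1ccc(-n2c(S)nnc2CSc2nnc(-c3ccccc3)n2-c2ccccc2)cc1` is not yet measured. It differs from compound 2 by fluoro in place of chloro on an aromatic carbon. Among the measured compounds shown here, no measured pair in this set exchanges one halogen for another, so the only guidance is that the single change recorded here, a substituent on an aromatic carbon, moved the number by less than the scatter. The step from compound 2 to compound 4 is therefore expected to be small, with no clear direction: a 1.1-fold higher number from compound 2 to compound 4 (0.04 log units; within the scatter). Compound 4 is estimated at 40000 nM, with a range from 18000 nM to 90000 nM.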

Compound 4, half-maximal inhibitory concentration: 16700 nM
For compound 4 the middle estimate is 2.4-fold (0.38 log units) above the measured one; measured number outside the range, below it.
By their numbers in this assay, from the lowest: compounds 4, 1, 2 and 3 (each within the scatter of the next, the first and the last beyond it).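

Among the changes followed so far, this is the first on an aromatic ring to move the number beyond the scatter: in this assay, replacing 4-chlorophenyl with 4-fluorophenyl gives a 2.2-fold lower number from compound 2 to compound 4 (0.34 log units; beyond the scatter). Among these compounds, the earlier ethoxy change, a 1.7-fold higher number from compound 1 to compound 3 (0.22 log units; within the scatter), stayed within the scatter, so the new step is the first sign that the group on an aromatic carbon, here para to a large group, can matter in this small set, although the step is only modest and compound 4 still has a high number. Nothing measured here explains why fluoro and chloro differ at this position.

One halogen exchange cannot show whether the number would keep moving the same way with bromo, or how it would respond to a very different group, such as an amine or a carboxylic acid, at the same place. As far as these compounds go, it also remains open whether fluoro in place of chloro would give a similar step on the core of compound 1, which differs from the core of compound 2 in how its parts are linked.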